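Vinyl at the imidazole carbon: step from compound 3 to 4

This account rests on a few compounds, and the source may have more. Where it says the series, first, only, none or still open, it means among the compounds named here.

Compound 3 `CCc1ncc2n1CCN([C@@H](C(=O)NC)c1ccccc1)C2CCc1ccc(C(F)(F)F)cc1` gives 194 nM in a functional assay on CHO cells for antagonist activity at Orexin receptor type 2 (Homo sapiens), read by FLIPR and calcium flux (on this read-out lower numbers stand for stronger inhibition and higher numbers for weaker inhibition), the second highest of the three numbers recorded. Nearest is compound 2 `CNC(=O)[C@@H](c1ccccc1)N1CCn2c(CC3CC3)nc(Cl)c2[C@@H]1CCc1ccc(C(F)(F)F)cc1` at 35 nM; furthest is compound 1 `CCOc1nc(CC)n2c1C(CCc1ccc(C(F)(F)F)cc1)N([C@@H](C(=O)NC)c1ccccc1)CC2` at 2750 nM. Compound 4 `C=Cc1nc(CC)n2c1C(CCc1ccc(C(F)(F)F)cc1)N([C@@H](C(=O)NC)c1ccccc1)CC2` differs from compound 3 by vinyl in place of hydrogen on an aromatic carbon. For the measured compounds named here, the only single-point step at this same aromatic carbon is the removal of ethoxy, a 14-fold lower number from compound 1 to compound 3 (1.15 log units; beyond the scatter), so a substituent there has once been seen to raise the number markedly. Compound 2 carries chlorine at that carbon yet also a cyclopropylmethyl group in place of ethyl, and its value differs from compound 3 in more than one place, so it cannot be read as a clean step. Vinyl is smaller than ethoxy and lacks its acceptor, so a weaker rise than the ethoxy step is expected, a 2.6-fold higher number from compound 3 to compound 4 (0.41 log units; beyond the scatter), with a wide band because only one relevant step exists. For compound 4 the expected value in this assay is 500 nM, within 150 nM to 2000 nM.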

Compound 4, half-maximal inhibitory concentration: 23 nM
The estimate for compound 4 lay 22-fold (1.34 log units) above the measured number; measured number below the stated range.
By their numbers in this assay, from the lowest: compounds 4 and 2 (each within the scatter of the next); then compound 3; then compound 1.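

In this assay, vinyl in place of hydrogen gives an 8.4-fold lower number from compound 3 to compound 4 (0.93 log units; beyond the scatter), so a substituent on this aromatic carbon does not always raise the number, as the ethoxy step alone might have suggested. Vinyl in place of ethoxy gives a 120-fold lower number from compound 1 to compound 4 (2.08 log units; beyond the scatter), which shows that the group at this carbon decides the direction of the change, with hydrogen lying between vinyl and ethoxy in this set of three compounds. Nothing at hand accounts for the opposite outcomes of vinyl and ethoxy at this carbon.

As far as these compounds go, whether the lower number needs the double bond stays open, and ethyl or ethynyl at this carbon, with the rest of compound 4 unchanged, would address that. From the compounds shown here alone, the effect of chlorine at this carbon also stays open, since compound 2 differs from compound 3 in more than one place.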